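The compounds below may be only part of what the source reports. "The series", "measured", "known", "first", "only" and "open" are said of these compounds alone.

Of the compounds shown here, two have been tested in a functional assay on A-375 cells (Homo sapiens) for cytotoxicity, read by MTT assay, with a stated time of 72 h, tested at 10 uM (on this read-out higher numbers stand for more inhibition of growth at the one concentration tested and lower numbers for less inhibition of growth), so far. Compound 1 `Cc1ccnc(/C(N)=N/NC(=S)N2CCSCC2)c1` gives 74.5% in this assay. Compound 2 `N/C(=N\NC(=S)N1CCCCC1)c1ccccn1` gives 85.8% in this assay, the higher of the two numbers, and the gap to compound 1 lies beyond the usual scatter. The two compounds differ in two places at once, so no single change can be read from that gap.

Compound 3 `Cc1ccnc(/C(N)=N/NC(=S)N2CCCCC2)c1` is the next one to be measured. It differs from compound 2 in a single place: methyl in place of hydrogen on an aromatic carbon. No change of the same kind has been measured here, so the effect of this step is open. Compound 1 also carries the methyl and gives 74.5%, but it differs from compound 3 in a second place as well, so it offers only a loose pointer. The expectation is that the step from compound 2 to compound 3 brings at most a small change, a number 5.8 percentage points lower from compound 2 to compound 3 (within the scatter), not clearly beyond the scatter. Compound 3 is therefore estimated to give about 80% in this assay, with a likely range from 66% to 91%.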

Compound 3, percent growth inhibition at one concentration: 81.2%
Compound 3: the middle estimate sits 1.2 percentage points below what was measured; the range from low to high includes it.
By their numbers in this assay, from the lowest: compounds 1, 3 and 2 (each within the scatter of the next, the first and the last beyond it).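

Adding the methyl on the aromatic carbon opposite the ring nitrogen gives a number 4.6 percentage points lower from compound 2 to compound 3 (within the scatter) in this assay, so a methyl at this position leaves growth inhibition without a clear change. Compound 3 also isolates the change on the thiocarbonyl carbon: piperidin-1-yl in place of thiomorpholin-4-yl gives a number 6.7 percentage points higher from compound 1 to compound 3 (within the scatter), so this single change likewise stays within the usual scatter. No accompanying measurement offers a reason for either step.

The compounds shown leave open whether a group other than methyl at this position, such as a methoxy group, a chlorine atom or an amine, would shift the number beyond the scatter. They also leave open how a morpholin-4-yl or piperazin-1-yl ring on the thiocarbonyl carbon would compare with piperidin-1-yl and thiomorpholin-4-yl.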